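From Hydrogen to Phenyl on the Shared Core

A few compounds are considered here, and "the series" means these few. Any claim that something is new, unique, unknown or untested is made for them only; others in the source may bear on it.

In an ADME assay on MDCKII-LE cells (Canis lupus familiaris) for permeability, in the apical to basolateral direction (a higher number here means that the compound crosses the layer faster, a lower number that the compound crosses the layer more slowly), compound 2 `O=c1cc(Cn2cnc3ccccc32)nc2sccn12` gives 17.3 10^-6 cm/s. Compound 1 `Cc1csc2nc(Cn3cnc4ccccc43)cc(=O)n12` gives 23.4 10^-6 cm/s and compound 3 `Cc1cn2c(=O)cc(Cn3cnc4ccccc43)nc2s1` gives 14.3 10^-6 cm/s, so compound 2 stands within the scatter of both. Compound 4 `O=c1cc(Cn2cnc3ccccc32)nc2scc(-c3ccccc3)n12` arises through (phenyl in place of hydrogen on an aromatic carbon), phenyl in place of hydrogen on an aromatic carbon, next to the ring nitrogen. Two methyl steps bear on this change: a 1.4-fold lower number from compound 1 to compound 2 (0.13 log units; within the scatter), which removes methyl from that same carbon, and a 1.2-fold lower number from compound 2 to compound 3 (0.08 log units; within the scatter), which adds methyl on another aromatic carbon. Both lie within the scatter, but no phenyl has yet been measured here. No step beyond the scatter is therefore expected in this assay, in either direction. The expected step is a 1.2-fold higher number from compound 2 to compound 4 (0.06 log units; within the scatter). For compound 4 the estimated value is 20 10^-6 cm/s, with an expected range from 9 10^-6 cm/s to 35 10^-6 cm/s.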

Compound 4, apparent permeability: 11.5 10^-6 cm/s
For compound 4 the middle estimate is 1.7-fold (0.24 log units) above the measured one; measured number inside the range.
By their numbers in this assay, from the lowest: compounds 4, 3, 2 and 1 (each within the scatter of the next, the first and the last beyond it).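

In this assay phenyl on this carbon gives a 1.5-fold lower number from compound 2 to compound 4 (0.18 log units; within the scatter) against hydrogen, and a 2.0-fold lower number from compound 1 to compound 4 (0.31 log units; beyond the scatter) against methyl, a modest step. The methyl steps had shown nothing beyond the scatter, so this is the first gap at this position to exceed it, and it appears only against methyl. Nothing shown here accounts for that gap.

Going by these compounds, whether an amine, a carboxylic acid or a longer chain on this carbon would stay within the scatter of compound 2 remains open, as does whether a substituted phenyl would stay within the scatter of compound 4.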